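Amide-ring variation in a benzoxazole thioether series

A few compounds are considered here, and "the series" means these few. Any claim that something is new, unique, unknown or untested is made for them only; others in the source may bear on it.

Three compounds carry the same thioether-linked core and differ at the amide end. In an ADME assay on microsomes from liver (Homo sapiens) for metabolic stability, read by LC-MS, using NADPH, with a stated time of 45 min, tested at 0.5 uM (on this read-out lower numbers stand for slow clearance and higher numbers for fast clearance), compound 3 `O=C(CCSc1nc2cc(Cl)ccc2o1)N1CCCCC1` gives 10.7 mL/min/g. Compound 2 `COc1ccc2oc(SCCC(=O)N3CCCC3)nc2c1` gives 6.1 mL/min/g in this assay, a gap to compound 3 that lies within the usual scatter, so the two are not distinguished. Compound 1 `CS(=O)(=O)C1CCN(C(=O)CCSc2nc3cc(Cl)ccc3o2)CC1` gives 0.5 mL/min/g in this assay, and the step of a 21-fold higher number from compound 1 to compound 3 (1.33 log units; beyond the scatter) is the only one beyond the scatter among these three.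

Compound 4 `O=C(CCSc1nc2cc(Cl)ccc2o1)N1CCS(=O)(=O)C1` has not yet been measured. Its change from compound 3 is 1,1-dioxo-1,3-thiazolidin-3-yl in place of piperidin-1-yl on a carbonyl carbon. Among the measured compounds shown here, the one measured step that bears on this is a 21-fold higher number from compound 1 to compound 3 (1.33 log units; beyond the scatter), where removal of a methylsulfonyl from the amide ring carbon went with a large rise; compound 4 again places a sulfonyl-bearing ring on the carbonyl carbon, though as a 1,1-dioxo-1,3-thiazolidin-3-yl rather than as a substituent on a piperidine. A drop in this assay of a similar order is therefore expected, with the ring size change leaving the exact size open.

Compound 4 is estimated to give 1.5 mL/min/g in this assay, with a range of 0.4 mL/min/g to 5 mL/min/g. That estimate means a step of a 7.1-fold lower number from compound 3 to compound 4 (0.85 log units; beyond the scatter), expected to fall beyond the scatter.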

Compound 4, intrinsic clearance in a liver preparation (reported as CLH), per the amount of preparation that the assay uses: 1.7 mL/min/g
Estimate against measurement, compound 4: 1.1-fold (0.05 log units) below; measured number inside the range.
By their numbers in this assay, from the lowest: compound 1; then compound 4; then compounds 2 and 3 (each within the scatter of the next).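

In this assay, 1,1-dioxo-1,3-thiazolidin-3-yl in place of piperidin-1-yl on a carbonyl carbon gives a 6.3-fold lower number from compound 3 to compound 4 (0.80 log units; beyond the scatter), which shows that a low number at this amide end does not depend on a methylsulfonyl group hanging from a six-membered ring. Read with a 21-fold higher number from compound 1 to compound 3 (1.33 log units; beyond the scatter), this means that both sulfonyl-bearing amide rings shown stand beyond the scatter from the piperidin-1-yl amide of compound 3, and neither goes against that pattern, though it rests on only these two rings. The new step changes several things at once, going from a six-membered to a five-membered ring, placing the sulfonyl inside the ring and going from 0 to 2 hydrogen-bond acceptors, and no measurement offered here explains why the number falls.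

The compounds shown do not separate the contribution of the sulfonyl group from that of the ring size, since no pair differs in only one of these features. From the compounds shown here alone, a morpholine amide, a thiomorpholine amide or a piperidine carrying a carboxylic acid would test whether the low numbers extend beyond sulfonyl-bearing rings, and a longer chain between the sulfur and the carbonyl remains unexplored in this set.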